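The source may hold more compounds than are shown below. What is called first, only, known or untested is meant among the compounds shown, and "the series" means these compounds.

Measured compounds in this series:

Compound 1, `FC(F)(F)c1ccc(-c2ccc3c(NCCCNCc4ccco4)ccnc3c2)cc1`, 9.47 in a physicochemical assay for acid dissociation.
Compound 2, `CC(C)(C)c1ccc(-c2ccc3c(NCCCNCc4ccco4)ccnc3c2)cc1`, 9.47 in this assay.
Compound 3, `COc1ccc(F)cc1CNCCCNc1ccnc2cc(-c3ccc(C(C)(C)C)cc3)ccc12`, 9.47 in this assay.

The three measured compounds share a core and sit level with one another in this assay. The move from compound 2 to compound 1 is trifluoromethyl in place of tert-butyl on an aromatic carbon, and it gives no change at the digits printed from compound 2 to compound 1 (within the scatter). The cores of compound 2 and compound 3 differ by 5-fluoro-2-methoxyphenyl in place of furan-2-yl on a saturated chain carbon bound to an amine nitrogen, with no change at the digits printed from compound 2 to compound 3 (within the scatter). Nothing among these values separates any of the three compounds.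

Compound 4, `COc1ccc(F)cc1CNCCCNc1ccnc2cc(-c3ccc(C(F)(F)F)cc3)ccc12`, is not yet measured in this assay. It differs from compound 3 by trifluoromethyl in place of tert-butyl on an aromatic carbon, the same change as that from compound 2 to compound 1, made on the core of compound 3 rather than on the core of compound 2. The place of the change is the same in both pairs. The expected step is no change at the digits printed from compound 3 to compound 4 (within the scatter), and this expectation rests on the earlier pair, since compound 1 against compound 2 showed no change at the digits printed from compound 2 to compound 1 (within the scatter). For compound 4 the expected value in this assay is 9.47, estimated between 9.2 and 9.75.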

Compound 4, acid dissociation constant: 9.47
Compound 4: middle estimate and measured number agree at the digits printed; the range from low to high includes it.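

Carried onto the core bearing 5-fluoro-2-methoxyphenyl, trifluoromethyl in place of tert-butyl on an aromatic carbon gives in this assay no change at the digits printed from compound 3 to compound 4 (within the scatter), the same outcome as on the core bearing furan-2-yl, no change at the digits printed from compound 2 to compound 1 (within the scatter). Read the other way round, 5-fluoro-2-methoxyphenyl in place of furan-2-yl gives no change at the digits printed from compound 1 to compound 4 (within the scatter), so the four compounds form a closed square with no step beyond the scatter on any side. This shows that the change stays silent on two cores in this one read-out, but with no step to carry it is a weak test of transfer and says nothing about a change that does move the value, and nothing at hand accounts for the level values.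

Still open, on these data alone, is whether an amine or a carboxylic acid in place of tert-butyl on the phenyl group would leave the value level in this assay. A longer chain carrying the amine nitrogens is equally unsettled, and so is whether any step found there would repeat on both cores.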